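This account rests on a few compounds, and the source may have more. Where it says the series, first, only, none or still open, it means among the compounds named here.

Measured compounds:
compound 1 `Cc1nc(C)n(CC(=O)N2CCN(c3sc(C(F)(F)F)nc3-c3nc4c(F)cccc4[nH]3)C[C@H]2C)n1`, 321 nM in a functional assay on Venous blood for antagonist activity at C-X-C chemokine receptor type 3 (Homo sapiens), read by flow cytometry, with a stated time of 30 min, in the presence of a further agent that is not named here; a higher number here means a weaker inhibitor, a lower number a stronger inhibitor
compound 2 `Cc1nc(C)n(CC(=O)N2CCN(c3sc(C(F)(F)F)nc3-c3nc4ccccc4[nH]3)C[C@H]2C)n1`, 237 nM
compound 3 `C[C@@H]1CN(c2sc(C(F)(F)F)nc2-c2nc3ccccc3[nH]2)CCN1C(=O)Cn1cnc2c1CCN(C)C2`, 135 nM

Compound 2 has the second highest of the three numbers in this assay: compound 1 differs from it by a 1.4-fold lower number from compound 1 to compound 2 (0.13 log units; within the scatter), and compound 3 by a 1.8-fold lower number from compound 2 to compound 3 (0.24 log units; within the scatter), both within the scatter, so the three compounds cannot be set apart on these data.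

Compound 4 `Cc1nc(C)n(CC(=O)N2CCN(c3sc(C(F)(F)F)nc3-c3nc4c(C(F)(F)F)cccc4[nH]3)C[C@H]2C)n1` is compound 2 with trifluoromethyl in place of hydrogen on an aromatic carbon. Among the measured compounds shown here, the only measured step that bears on this change is a 1.4-fold lower number from compound 1 to compound 2 (0.13 log units; within the scatter), in which a fluoro on the same aromatic carbon was exchanged for hydrogen; it lay within the scatter. For the measured compounds named here, the change from compound 2 to compound 4 adds a larger group at that carbon, but no measured compound carries a trifluoromethyl there, so nothing beyond that one step informs the expectation. On that basis a step of about a 1.5-fold higher number from compound 2 to compound 4 (0.17 log units; within the scatter) is expected, toward a somewhat higher number, most likely still within the scatter. Compound 4 is therefore expected to give 350 nM in this assay, with a range from 150 nM to 900 nM.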

Compound 4, half-maximal inhibitory concentration: 747 nM
For compound 4 the middle estimate is 2.1-fold (0.33 log units) below the measured one, within the range that was stated.
By their numbers in this assay, from the lowest: compounds 3, 2 and 1 (each within the scatter of the next, the first and the last beyond it); then compound 4.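

In this assay, among the compounds shown here, fluoro and hydrogen on this aromatic carbon could not be told apart (a 1.4-fold lower number from compound 1 to compound 2 (0.13 log units; within the scatter)), so the earlier compounds showed no response to change at this position. Trifluoromethyl gives the first step here that lies beyond the scatter, and it does so against both of the smaller substituents, against hydrogen (a 3.2-fold higher number from compound 2 to compound 4 (0.50 log units; beyond the scatter)) and against fluoro (a 2.3-fold higher number from compound 1 to compound 4 (0.37 log units; beyond the scatter)), each time toward a weaker inhibitor, though only modestly. Nothing measured here explains these two steps.

With only hydrogen, fluoro and trifluoromethyl at this carbon, the compounds leave open whether a methyl, a chloro or a methoxy group there would stay level with compound 2 or move toward compound 4. They also leave open whether trifluoromethyl at this carbon would give a step of similar size when paired with the side chain of compound 3, or whether an amine or a carboxylic acid at the same carbon would move the number the other way.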